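Aryl group on the aromatic nitrogen: compound 3 to compound 4

The compounds below may be only part of what the source reports. "The series", "measured", "known", "first", "only" and "open" are said of these compounds alone.

Measured in an ADME assay on L02 cells (Homo sapiens) for antiproliferative activity, read by MTT assay, with a stated time of 48 h; on this read-out higher numbers stand for weaker inhibition and lower numbers for stronger inhibition:
Compound 1 `CC(=O)Nc1ccc(-n2nncc2CN2C(=O)C3(C(C#N)=C(N)Oc4c(N)cc5nc6ccccc6nc5c43)c3ccccc32)cc1` gives > 50000 nM, a limit of the assay.
Compound 2 `Cc1ccc(C)c(-n2nncc2CN2C(=O)C3(C(C#N)=C(N)Oc4c(N)cc5nc6ccccc6nc5c43)c3ccccc32)c1` gives > 50000 nM, also a limit of the assay.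
Compound 3 `N#CC1=C(N)Oc2c(N)cc3nc4ccccc4nc3c2C12C(=O)N(Cc1cnnn1-c1ccc([N+](=O)[O-])cc1[N+](=O)[O-])c1ccccc12` gives 22800 nM.

Within the data shown here, compound 3 is thus the only member with a number in this assay; the other two sit at a limit (the limit of > 50000 nM in this assay, at which 2 of the 3 values shown sit). The steps toward it are an at least 2.1-fold lower number from compound 1 to compound 3 (0.34 log units; beyond the scatter) and an at least 2.1-fold lower number from compound 2 to compound 3 (0.34 log units; beyond the scatter), each beyond the scatter, while the pair of limits gives a step that the two limits leave unreadable from compound 1 to compound 2.

Compound 4 `COc1cc(-n2nncc2CN2C(=O)C3(C(C#N)=C(N)Oc4c(N)cc5nc6ccccc6nc5c43)c3ccccc32)c(OC)cc1Cl` carries 4-chloro-2,5-dimethoxyphenyl in place of 2,4-dinitrophenyl on an aromatic nitrogen. The new aryl group, a 4-chloro-2,5-dimethoxyphenyl, lacks the nitro groups that distinguish compound 3 from compound 1 and compound 2. Both measured steps toward compound 3 lowered the number by at least a modest amount; the move away from the dinitrophenyl is therefore expected to raise it again. The step from compound 3 is estimated as a 2.0-fold higher number from compound 3 to compound 4 (0.30 log units; within the scatter). Compound 4 is expected to give about 45000 nM, within 20000 nM to 100000 nM, with a real chance that only a limit is returned.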

Compound 4, half-maximal inhibitory concentration: > 50000 nM
Compound 4: a limit, no number; the forecaster's own chance of this, stated with the estimate: 50%; middle value at least 1.1-fold (0.04 log units) away from the limit.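

In this assay, 4-chloro-2,5-dimethoxyphenyl in place of 2,4-dinitrophenyl on the aromatic nitrogen gives an at least 2.1-fold higher number from compound 3 to compound 4 (0.34 log units; beyond the scatter). A chlorine-bearing dimethoxy aryl group thus joins the 2,5-dimethylphenyl and 4-acetamidophenyl groups in giving no number, leaving the 2,4-dinitrophenyl of compound 3 as the only aryl group shown with a measured value. The steps among compound 1, compound 2 and compound 4 cannot be read, and the limit now dominates the series: the limit of > 50000 nM in this assay, at which 3 of the 4 values shown sit.

Going by these compounds, how far compound 1, compound 2 and compound 4 lie beyond that limit remains unknown, so no order among them can be given. On these data alone, it also remains open whether both nitro groups are needed for a number, and whether an aryl ring with a single nitro group, a trifluoromethyl group or a carboxylic acid would give one.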